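Carbamoyl for 2-Fluorophenyl: Expected Cytotoxicity of Compound 3

This account rests on a few compounds, and the source may have more. Where it says the series, first, only, none or still open, it means among the compounds named here.

In an ADME assay on MT4 cells (Homo sapiens) for cytotoxicity, read by MTT assay, with a stated time of 5 days (on this read-out lower numbers stand for higher toxicity in this test and higher numbers for lower toxicity in this test), compound 1 (`Cc1cc(C)cc(S(=O)(=O)c2c(C(=O)N[C@H]3CCNC3)[nH]c3ccc(Cl)cc23)c1`) gives 10000 nM as a true number. Compound 2 (`Cc1cc(C)cc(S(=O)(=O)c2c(C(=O)N[C@@H]3CCN(Cc4ccccc4F)C3)[nH]c3ccc(Cl)cc23)c1`) gives > 231000 nM and this is a limit of the assay, not a number, at the low-toxicity end of the two results. Compound 3 (`Cc1cc(C)cc(S(=O)(=O)c2c(C(=O)N[C@@H]3CCN(CC(N)=O)C3)[nH]c3ccc(Cl)cc23)c1`) has carbamoyl in place of 2-fluorophenyl on a saturated chain carbon bound to an amine nitrogen in a ring. For the measured compounds named here, no measured pair shows this change. Going by the values given here, compound 1 at 10000 nM is the only true number, so a result toward it seems likely. A small move toward higher toxicity is expected, an at least 2.3-fold lower number from compound 2 to compound 3 (0.36 log units; beyond the scatter) in size. In this assay the expected value for compound 3 is 100000 nM with a range from 20000 nM to 260000 nM as estimated.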

Compound 3, half-maximal cytotoxic concentration: 31000 nM
For compound 3 the middle estimate is 3.2-fold (0.51 log units) above the measured one, within the range that was stated.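

In this assay there is a step of an at least 7.4-fold lower number from compound 2 to compound 3 (0.87 log units; beyond the scatter), so the group on this chain carbon does change the read-out, and carbamoyl ends on the more toxic side of 2-fluorophenyl. From the compounds shown here alone, the true size of that step stays unknown because compound 2 sits at a limit of the assay: the limit of > 231000 nM in this assay, at which 1 of the 3 values shown sits. Carbamoylmethyl on the ring nitrogen still leaves a 3.1-fold higher number from compound 1 to compound 3 (0.49 log units; beyond the scatter), so compound 3 lies above the parent amine.

Going by these compounds, whether a carboxylic acid, an amine or a longer chain at this place would give a number nearer compound 1 stays open.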